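Swapping ethyl for methoxy on a short-lived compound

This account rests on a few compounds, and the source may have more. Where it says the series, first, only, none or still open, it means among the compounds named here.

compound 1 `CCc1nc(-c2ccc(OC(F)(F)F)cc2OC)c(CC)nc1NC(CC)CC` with 0.0417 h
compound 2 `CCc1nc(-c2ccc(Cl)cc2Cl)c(CC)nc1NC(COC)COC` with 0.0417 h
compound 3 `CCc1nc(-c2ccc(OC)cc2O)c(CC)nc1NC(CC)CC` with 0.0983 h

In an in vitro ADME assay on microsomes (Rattus norvegicus) for metabolic stability (a lower number here means that the compound disappears faster, a higher number that the compound lasts longer), compound 2 sits level with compound 1 at 0.0417 h and these two share the lowest of the three numbers. Compound 3 gives 0.0983 h and so lasts longer than compound 1, a gap beyond the usual scatter. Compound 4 `CCc1nc(-c2ccc(OC(F)(F)F)cc2OC)c(OC)nc1NC(CC)CC` has yet to be measured. It differs from compound 1 by methoxy in place of ethyl on an aromatic carbon with methoxy in place of ethyl on an aromatic carbon, next to the ring nitrogen. Among the compounds with values here, no two measured compounds differ in one place only, so direct guidance is missing. The expected step is a 1.4-fold higher number from compound 1 to compound 4 (0.16 log units; within the scatter) and so small, perhaps nothing beyond the scatter. The estimate for compound 4 is 0.06 h as a middle value, with an expected range from 0.035 h to 0.12 h around it.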

Compound 4, half-life: 0.6 h
Compound 4: the middle estimate sits 10-fold (1.00 log units) below what was measured; the measured number lies above the stated range.
By their numbers in this assay, from the lowest: compounds 1 and 2 (each within the scatter of the next); then compound 3; then compound 4.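

In this assay this single place, next to the ring nitrogen, proves highly sensitive: methoxy in place of ethyl brings a 14-fold higher number from compound 1 to compound 4 (1.16 log units; beyond the scatter) even though both groups count the same number of heavy atoms. The earlier compounds shown here differ from one another in more than one place, so they could not isolate this change. No measurement shown here explains the step. From the compounds shown here alone, it remains open whether an amine or a longer chain such as propyl at this place would last similarly. Going by these compounds, whether methoxy here would bring a similar step with the other parts of compound 2 or compound 3 also remains open.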